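A few compounds are considered here, and "the series" means these few. Any claim that something is new, unique, unknown or untested is made for them only; others in the source may bear on it.

Measured so far:
- compound 1 `COc1ccc(N(C)c2nc(N)nc3c2CC(C)C3)cc1`: 29.9 nM
- compound 2 `Cc1ccc(N(C)c2ncnc3c2CCC3)cc1`: "not determined" (no result reported)
- compound 3 `Cc1ccc(N(C)c2nc(C)nc3c2CCC3)cc1`: 360 nM

Not yet measured:
- compound 4 `CCOc1ccc(N(C)c2ncnc3c2CCC3)cc1`

In a functional assay on MDA-MB-435 cells (Homo sapiens) for inhibition, read by sulforhodamine B assay, with a stated time of 48 h (on this read-out lower numbers stand for stronger inhibition and higher numbers for weaker inhibition), compound 2 has no number, its entry being "not determined" (no result reported), so the step below has no measured starting point. The structural change ethoxy in place of methyl on an aromatic carbon puts ethoxy in place of methyl on an aromatic carbon. Methoxy-bearing compound 1 gives 29.9 nM and methyl-bearing compound 3 gives 360 nM, but these two differ in more than one place, so the gap is only a weak guide. A moderate step towards stronger inhibition, beyond the scatter, is expected. In this assay the estimate for compound 4 is 250 nM, expected within 50 nM to 1200 nM.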

Compound 4, half-maximal inhibitory concentration: 48.7 nM
The estimate for compound 4 lay 5.1-fold (0.71 log units) above the measured number; measured number outside the range, below it.
By their numbers in this assay, from the lowest: compounds 1 and 4 (each within the scatter of the next); then compound 3.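

Within the data shown here, compound 2 has no number, so no step to compound 4 can be read. What ethoxy in place of methyl does to inhibition stays open, and no measurement shown gives a cause for the result of compound 4.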